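The source may report more compounds than this note shows. Statements on the series, on what has been measured and on what is new or still open speak of the compounds shown alone.

Measured compounds:
- compound 1 `CCCCNc1nc(-c2ccccc2)nc2c1nnn2Cc1ccccc1F` — in an assay on Cerebral cortex for displacement of a labelled ligand from adenosine receptor A1 (Bos taurus) (a higher number here means a weaker inhibitor, a lower number a stronger inhibitor), compound 1 gives 4.3 nM
- compound 2 `Clc1ccccc1Cn1nnc2c(NC3CC3)nc(-c3ccccc3)nc21` — in this assay compound 2 gives 11 nM

Compound 2 stands highest of the two numbers recorded in this assay; compound 1 sits lower, and the gap between the two lies beyond the scatter. Within the data shown here, the two compounds differ in more than one place, so no single step between them can be read off.

Compound 3 `Fc1ccccc1Cn1nnc2c(NC3CC3)nc(-c3ccccc3)nc21` has not been measured. Its difference from compound 2 is fluoro in place of chloro on an aromatic carbon. Among the measured compounds shown here, no measured pair shows this exact difference on this core, so the expectation rests only on the two values above. A step of modest size is expected, pointing toward a lower number if anything, and most likely within the scatter: a 1.6-fold lower number from compound 2 to compound 3 (0.20 log units; within the scatter) is the step expected from compound 2 to compound 3 in this assay. The estimate for compound 3 in this assay is 7 nM, in the range 3 nM to 18 nM.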

Compound 3, inhibition constant: 15 nM
For compound 3 the middle estimate is 2.1-fold (0.33 log units) below the measured one, within the range that was stated.
By their numbers in this assay, from the lowest: compound 1; then compounds 2 and 3 (each within the scatter of the next).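

In this assay the change from 2-chlorobenzyl to 2-fluorobenzyl, with cyclopropyl on the nitrogen, gives a 1.4-fold higher number from compound 2 to compound 3 (0.13 log units; within the scatter) and so does not separate chloro from fluoro at this position. Among these compounds, compound 3 also makes the nitrogen substituent readable with 2-fluorobenzyl held constant: cyclopropyl in place of butyl gives a 3.5-fold higher number from compound 1 to compound 3 (0.54 log units; beyond the scatter) and is the only single change here that lies beyond the scatter. No measurement at hand accounts for either step.

Still open, going by these compounds, is whether bromo, methyl or methoxy on that same aromatic carbon would stay with chloro and fluoro or fall apart from them. Also open, on these data alone, is how a longer chain such as hexyl, or a cyclopentyl group, on the nitrogen would compare with butyl and cyclopropyl.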